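This account rests on a few compounds, and the source may have more. Where it says the series, first, only, none or still open, it means among the compounds named here.

Measured compounds:
- compound 1 `C=CCO/N=C/c1c(N)ncnc1Oc1ccc2[nH]c(C)cc2c1F`: 42 nM
- compound 2 `CO/N=C/c1c(N)ncnc1Oc1ccc2[nH]c(C)cc2c1`: 388 nM
- compound 3 `CO/N=C/c1c(N)ncnc1Oc1ccc2[nH]ccc2c1`: 1870 nM

All three were tested in a functional assay on HeLa cells (Homo sapiens) for antiproliferative activity; a higher number here means a weaker inhibitor, a lower number a stronger inhibitor. Compound 1 gives the lowest number of the three, so on these numbers it is the strongest inhibitor: compound 2 sits well above it, and compound 3 higher still. Within the data shown here, the only single change among the measured compounds is the one from compound 2 to compound 3, where hydrogen replaces methyl on an aromatic carbon, and it brought a 4.8-fold higher number from compound 2 to compound 3 (0.68 log units; beyond the scatter).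

Compound 4 `COCCCO/N=C/c1c(N)ncnc1Oc1ccc2[nH]c(C)cc2c1F` is not yet measured. It differs from compound 1 at the allyloxy chain on the oxime: 2-methoxyethyl in place of vinyl on a saturated chain carbon bound to an oxygen on an unsaturated carbon. Cut one bond further out, the same change reads allyl to 3-methoxypropyl. Among the measured compounds shown here, no measured step touches this chain; the step from compound 2 to compound 3 concerns a different part of the shared core and says nothing about lengthening the chain or adding an oxygen to it. With no guidance either way, the expectation is a step of about a 1.4-fold higher number from compound 1 to compound 4 (0.15 log units; within the scatter), that is, no change beyond the scatter, while allowing a wider band for the untested chain. Compound 4 is therefore expected to give about 60 nM, with a range from 15 nM to 250 nM.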

Compound 4, half-maximal inhibitory concentration: 346 nM
Beside the measured number, compound 4's estimate is 5.8-fold (0.76 log units) below it; the measured number lies above the stated range.
By their numbers in this assay, from the lowest: compound 1; then compounds 4 and 2 (each within the scatter of the next); then compound 3.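

The chain on the oxime is not a silent position: in this assay, the change from allyl to 3-methoxypropyl brought an 8.2-fold higher number from compound 1 to compound 4 (0.92 log units; beyond the scatter) while the rest of the molecule stayed the same. Among these compounds, the only earlier step concerned a methyl group on the shared core, so this is the first evidence that the number also responds to a change in this chain, and here the change from the allyl chain made the compound a weaker inhibitor. Nothing measured here explains why the number rose at this position.

This single step swaps vinyl for 2-methoxyethyl, so it lengthens the chain, removes its double bond and adds an oxygen all at once, and a plain butyl chain would be needed to begin to tell these changes apart. From the compounds shown here alone, it also remains open how the number would respond to a different group at the end of the chain, such as an amine or a carboxylic acid in place of the methoxy group.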